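This account rests on a few compounds, and the source may have more. Where it says the series, first, only, none or still open, it means among the compounds named here.

Measured so far in an assay on brain for binding affinity to Neuronal acetylcholine receptor; alpha4/beta2 (Rattus norvegicus), read by radioligand binding; a higher number here means a weaker inhibitor, a lower number a stronger inhibitor:
- compound 1 `FC(F)(F)c1cncc(OC[C@@H]2CCN2)c1`: 0.49 nM
- compound 2 `CCCc1cncc(OC[C@@H]2CCN2)c1`: 0.039 nM

Among the measured compounds shown here, compound 2 holds the lowest number of the two; the only measured step is a 13-fold lower number from compound 1 to compound 2 (1.10 log units; beyond the scatter), a change on the same aromatic carbon. Compound 3 `c1ccc(-c2cncc(OC[C@@H]3CCN3)c2)cc1` carries the change (phenyl in place of propyl on an aromatic carbon). For the measured compounds named here, no measured step covers a phenyl at that position, so the step from propyl to trifluoromethyl is the only reference, and it shows that this carbon tolerates a change of group with a large shift. Compound 3 is estimated at 0.4 nM, within 0.06 nM to 2.5 nM. The expected step is a 10-fold higher number from compound 2 to compound 3 (1.01 log units; beyond the scatter), a weakening toward the range of compound 1.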

Compound 3, inhibition constant: 0.046 nM
For compound 3 the middle estimate is 8.7-fold (0.94 log units) above the measured one; the whole stated range lies above it.
By their numbers in this assay, from the lowest: compounds 2 and 3 (each within the scatter of the next); then compound 1.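

In this assay, this aromatic carbon accepts phenyl as readily as propyl: a 1.2-fold higher number from compound 2 to compound 3 (0.07 log units; within the scatter) stays small even though the entering group adds heavy atoms and a six-membered aromatic ring. The other step, an 11-fold lower number from compound 1 to compound 3 (1.03 log units; beyond the scatter), shows that compound 1 with trifluoromethyl stands apart from both compounds with a group of carbon only, not just from the propyl compound. The data offer no measured explanation for these steps.

Going by these compounds, it remains open whether a longer chain, such as hexyl, or a phenyl carrying an amine keeps the number this low. Any limit on the size of the group at this carbon also remains undefined.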